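The source may report more compounds than this note shows. Statements on the series, on what has been measured and on what is new or still open speak of the compounds shown alone.

Compound 1 `O=S(=O)(c1ccccc1)c1nc2ccccc2nc1N1CCCC(O)C1`: 3590 nM
Compound 2 `Cc1ccc(S(=O)(=O)c2nc3ccccc3nc2N2CCCC(O)C2)cc1`: 6080 nM

In a functional assay on KB cells (Homo sapiens) for cytotoxicity, read by MTT assay, with a stated time of 72 h (on this read-out lower numbers stand for stronger inhibition and higher numbers for weaker inhibition), compound 2 gives 6080 nM, which lies within the scatter of compound 1 at 3590 nM. Compound 3 `COc1ccc(S(=O)(=O)c2nc3ccccc3nc2N2CCCC(O)C2)cc1` differs from compound 2 by one change, (methoxy in place of methyl on an aromatic carbon), methoxy in place of methyl on an aromatic carbon. Among the measured compounds shown here, only one measured step bears on this: a 1.7-fold higher number from compound 1 to compound 2 (0.23 log units; within the scatter), methyl in place of hydrogen on an aromatic carbon. With so small a precedent, no step beyond the scatter is expected in this assay. The expected change is a 1.3-fold lower number from compound 2 to compound 3 (0.10 log units; within the scatter). For compound 3 the estimated value is 4800 nM, with an expected range of 2000 nM to 11000 nM.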

Compound 3, half-maximal inhibitory concentration: 2120 nM
Compound 3: the middle estimate sits 2.3-fold (0.35 log units) above what was measured; low and high end bracket the measured number.
By their numbers in this assay, from the lowest: compounds 3, 1 and 2 (each within the scatter of the next, the first and the last beyond it).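

Methoxy in place of methyl gives a 2.9-fold lower number from compound 2 to compound 3 (0.46 log units; beyond the scatter) and is the first change at this position on the aromatic ring to pass the scatter. Methoxy in place of hydrogen gives a 1.7-fold lower number from compound 1 to compound 3 (0.23 log units; within the scatter) and stays within it, so methoxy and methyl differ from each other more clearly than either differs from hydrogen. Nothing available explains this difference between the two groups. From the compounds shown here alone, whether an amine, a carboxylic acid or a longer chain at this position would move the number further remains open.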